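Swapping the aryl amide substituent in a cytotoxicity series

The source may hold more compounds than are shown below. What is called first, only, known or untested is meant among the compounds shown, and "the series" means these compounds.

Compound 1 `Cc1cc(S(N)(=O)=O)ccc1NC(=O)COc1ccc(Cl)cc1NC(=O)c1cccc(Cl)c1` is the reference point of this comparison. In a functional assay on C8166 cells (Homo sapiens) for cytotoxicity, read by MTT assay (a lower number here means that less compound is tolerated, a higher number that more compound is tolerated), compound 1 gives 59700 nM, the lowest of the three numbers recorded so far. Compound 2 `COc1ccc(C(=O)Nc2cc(Cl)ccc2OCC(=O)Nc2ccc(S(N)(=O)=O)cc2C)cc1` gives 69500 nM in this assay, and compound 3 `Cc1ccc(C(=O)Nc2cc(Cl)ccc2OCC(=O)Nc2ccc(S(N)(=O)=O)cc2C)cc1C` gives 84100 nM. The steps of a 1.2-fold higher number from compound 1 to compound 2 (0.07 log units; within the scatter) and a 1.4-fold higher number from compound 1 to compound 3 (0.15 log units; within the scatter) both stay within the scatter, as does a 1.2-fold higher number from compound 2 to compound 3 (0.08 log units; within the scatter), so the three measured compounds are not separated by this read-out.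

Compound 4 `Cc1cc(C)cc(C(=O)Nc2cc(Cl)ccc2OCC(=O)Nc2ccc(S(N)(=O)=O)cc2C)c1` has not yet been measured. Its difference from compound 1 is 3,5-dimethylphenyl in place of 3-chlorophenyl on a carbonyl carbon. The closest measured precedent is the step of a 1.4-fold higher number from compound 1 to compound 3 (0.15 log units; within the scatter), where 3,4-dimethylphenyl entered on the same carbonyl carbon, and the exchange for 4-methoxyphenyl in a 1.2-fold higher number from compound 1 to compound 2 (0.07 log units; within the scatter) was likewise small. Neither precedent moved the number beyond the scatter, so no step beyond the scatter is expected here either; if anything, a slightly higher number, in line with compound 3, is the expectation. The estimate for compound 4 is therefore 75000 nM, with a range from 40000 nM to 140000 nM, which corresponds to an expected step of a 1.3-fold higher number from compound 1 to compound 4 (0.10 log units; within the scatter).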

Compound 4, half-maximal cytotoxic concentration: 36500 nM
Estimate against measurement, compound 4: 2.1-fold (0.31 log units) above, and the stated range ends above it.
By their numbers in this assay, from the lowest: compounds 4, 1, 2 and 3 (each within the scatter of the next, the first and the last beyond it).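

Within the data shown here, on the carbonyl carbon of the shared core, the move from 3,4-dimethylphenyl to 3,5-dimethylphenyl gives in this assay a 2.3-fold lower number from compound 3 to compound 4 (0.36 log units; beyond the scatter) and is the only step in this set that passes the scatter, although the two groups differ only in the numbers in their names. The other two steps, a 1.6-fold lower number from compound 1 to compound 4 (0.21 log units; within the scatter) and a 1.9-fold lower number from compound 2 to compound 4 (0.28 log units; within the scatter), stay within the scatter, so compound 4 is set apart from compound 3 alone and not from compound 1 or compound 2. Among these compounds, this position therefore shows a modest response to where the two methyl groups stand on the phenyl ring, which the earlier compounds, all within the scatter of one another, did not show.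

The compounds shown carry only substituted phenyl groups on this carbonyl carbon, so it remains open whether an amine, a carboxylic acid or a longer chain in that place would move the number further, or whether other dimethylphenyl patterns would separate as compound 3 and compound 4 do. The data shown offer no explanation for the gap between compound 3 and compound 4.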